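A Methoxyphenyl Swap Tested on the Weakest Analogue

A few compounds are considered here, and "the series" means these few. Any claim that something is new, unique, unknown or untested is made for them only; others in the source may bear on it.

Among the measured compounds shown here, compound 2 `Cc1nn(-c2nc(-c3ccc(Cl)c(Cl)c3)c(SC(C)C)s2)c(C(=O)O)c1-c1cncc(C#N)c1` has the highest number of the two measured so far in a functional assay on BJAB cells (Homo sapiens) for antiproliferative activity, with a stated time of 4 days; a higher number here means that more compound is needed for the effect, a lower number that less compound is needed: compound 2 gives 20000 nM. For the measured compounds named here, its only neighbour, compound 1 `Cc1cc(Cl)cc(-c2c(C)nn(-c3nc(-c4ccc(Cl)c(Cl)c4)c(SC(C)C)s3)c2C(=O)O)c1`, gives 663 nM, and the sole measured step is a 30-fold higher number from compound 1 to compound 2 (1.48 log units; beyond the scatter). Compound 3 `COc1ccccc1-c1c(C)nn(-c2nc(-c3ccc(Cl)c(Cl)c3)c(SC(C)C)s2)c1C(=O)O` differs from compound 2 by 2-methoxyphenyl in place of 5-cyanopyridin-3-yl on an aromatic carbon, so it returns to a six-membered aromatic ring of carbon only, as in compound 1. Because the step of a 30-fold higher number from compound 1 to compound 2 (1.48 log units; beyond the scatter) was large, compound 3 is expected to move back down by a large margin, a 17-fold lower number from compound 2 to compound 3 (1.22 log units; beyond the scatter). Compound 3 is estimated at 1200 nM, ranging from 300 nM to 6000 nM.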

Compound 3, half-maximal effective concentration: 14700 nM
Estimate against measurement, compound 3: 12-fold (1.09 log units) below; measured number outside the range, above it.
By their numbers in this assay, from the lowest: compound 1; then compounds 3 and 2 (each within the scatter of the next).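

In this assay, a six-membered aromatic ring of carbon only at this position does not by itself bring the number back, since 2-methoxyphenyl in place of 3-chloro-5-methylphenyl still gives a 22-fold higher number from compound 1 to compound 3 (1.35 log units; beyond the scatter) and the change is large. Swapping 5-cyanopyridin-3-yl for 2-methoxyphenyl gives only a 1.4-fold lower number from compound 2 to compound 3 (0.13 log units; within the scatter) and stays within the scatter, so these two groups cannot be told apart here. No available measurement explains the difference from 3-chloro-5-methylphenyl. Going by these compounds, it remains open whether a plain phenyl, or a phenyl carrying only chloro or only methyl, would match compound 1.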